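A few compounds are considered here, and "the series" means these few. Any claim that something is new, unique, unknown or untested is made for them only; others in the source may bear on it.

In a functional assay on M21 cells (Homo sapiens) for antiproliferative activity, read by sulforhodamine B assay, with a stated time of 48 h (a higher number here means a weaker inhibitor, a lower number a stronger inhibitor), compound 2 `CCN1CCN(c2ccc(S(=O)(=O)Oc3cccc(OC)c3)cc2)C1=O` gives 7000 nM, and compound 3 `CCN1CCN(c2ccc(S(=O)(=O)Oc3cc(OC)cc(OC)c3)cc2)C1=O` gives 4200 nM, so these two are level within the scatter. Compound 1 `COc1cccc(OS(=O)(=O)c2ccc(N3CCN(C)C3=O)cc2)c1` gives 1600 nM, a real gap: a 4.4-fold higher number from compound 1 to compound 2 (0.64 log units; beyond the scatter). That step changes a different place in the molecule, so it says little here. Compound 4 `CCN1CCN(c2ccc(S(=O)(=O)Oc3ccc(OC)cc3)cc2)C1=O` has the same atoms as compound 2, joined differently: 4-methoxyphenyl in place of 3-methoxyphenyl on an oxygen. Within the data shown here, no measured step shows what this exchange does. The closest evidence is the added methoxy on that aromatic ring, a 1.7-fold lower number from compound 2 to compound 3 (0.22 log units; within the scatter), which stayed within the scatter. A small change is therefore expected, with no shift beyond the scatter: a 1.4-fold lower number from compound 2 to compound 4 (0.15 log units; within the scatter). Compound 4 is estimated at 5000 nM, with an expected range of 1800 nM to 14000 nM.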

Compound 4, half-maximal inhibitory concentration: 26000 nM
The estimate for compound 4 lay 5.2-fold (0.72 log units) below the measured number; the measured number lies above the stated range.
By their numbers in this assay, from the lowest: compound 1; then compounds 3 and 2 (each within the scatter of the next); then compound 4.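

Exchanging 3-methoxyphenyl for 4-methoxyphenyl on the oxygen bound to the sulfonyl sulfur leaves the atoms unchanged, yet this assay shows a 3.7-fold higher number from compound 2 to compound 4 (0.57 log units; beyond the scatter). Among these compounds, the earlier step on this ring, the added methoxy of compound 3, stayed within the scatter, so this is the first sign that the place of the methoxy on the ring matters. Nothing measured here explains the difference. Still open, on these data alone, is how this ring responds to a different group, such as an amine or a carboxylic acid. Also open, as far as these compounds go, is whether 4-methoxyphenyl has the same effect on the core of compound 1.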